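Swapping the aryl on the triazole of an inactive pair

The compounds below may be only part of what the source reports. "The series", "measured", "known", "first", "only" and "open" are said of these compounds alone.

Compound 1 `N#CC1=C(N)Oc2c(c3nc4ccccc4nc3c3ccccc23)C12C(=O)N(Cc1cnnn1-c1ccc(Br)cc1)c1ccccc12` gives > 50000 nM in a functional assay on HepG2 cells (Homo sapiens) for antiproliferative activity, read by MTT assay, with a stated time of 48 h; on this read-out higher numbers stand for weaker inhibition and lower numbers for stronger inhibition.
Compound 2 `COc1ccc(-n2nncc2CN2C(=O)C3(C(C#N)=C(N)Oc4c(N)cc5nc6ccccc6nc5c43)c3ccccc32)cc1` gives > 50000 nM in this assay.

Both numbers are limits of the assay rather than measured values. Compound 1 stops at the limit > 50000 nM. Compound 2 also stops at the limit > 50000 nM. Among the compounds with values here, the two therefore sit together at the limit of > 50000 nM in this assay, at which 2 of the 2 values shown sit, and no step between measured compounds exists to show how a change in structure moves the read-out.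

Compound 3 `Cc1ccc(Cl)cc1-n1nncc1CN1C(=O)C2(C(C#N)=C(N)Oc3c(N)cc4nc5ccccc5nc4c32)c2ccccc21` differs from compound 2 in one place: 5-chloro-2-methylphenyl in place of 4-methoxyphenyl on an aromatic nitrogen. With compound 2 showing only the limit > 50000 nM in this assay, the move from compound 2 to compound 3 is expected to be no more than a small one, a step that the limit leaves unreadable from compound 2 to compound 3. Compound 3 is expected to give about 60000 nM, within 20000 nM to 200000 nM, and most likely the assay will again report only a limit.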

Compound 3, half-maximal inhibitory concentration: 17300 nM
Compound 3: the middle estimate sits 3.5-fold (0.54 log units) above what was measured, and the stated range ends above it.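

This aromatic nitrogen proves to be a place where the choice of aryl group can change the read-out: in this assay, 5-chloro-2-methylphenyl in place of 4-methoxyphenyl gives an at least 2.8-fold lower number from compound 2 to compound 3 (0.46 log units; beyond the scatter). Compound 3 is therefore the only compound shown with a measured number rather than a limit, so the core it shares with compound 2 can reach a readable level of activity on these cells when it carries this aryl group. The true size of the step stays unknown, and the printed figure is only its smallest possible size, because compound 2 stops at a limit: the limit of > 50000 nM in this assay, at which 2 of the 3 values shown sit.

The change removes a methoxy group and brings in both a chlorine and a methyl, so the compounds shown cannot tell which of these matters. As far as these compounds go, it remains open how a plain phenyl, or a phenyl carrying only the methyl or only the chlorine, would behave at this place.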